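Swapping the Acyl Aryl Group: Expected Cytotoxicity of Compound 3

The source may report more compounds than this note shows. Statements on the series, on what has been measured and on what is new or still open speak of the compounds shown alone.

Compound 1 `Cc1ccc(-c2nn(-c3ccccc3)cc2-c2nc3ccccc3n2C(=O)c2ccc(Cl)cc2)cc1`: 216000 nM
Compound 2 `Cc1ccc(-c2nn(-c3ccccc3)cc2-c2nc3ccccc3n2C(=O)c2ccc(C)nc2)cc1`: 145000 nM

In an ADME assay on HEK-293T cells (Homo sapiens) for cytotoxicity, read by MTT assay, with a stated time of 24 h (on this read-out lower numbers stand for higher toxicity in this test and higher numbers for lower toxicity in this test), compound 1 gives 216000 nM while compound 2 gives 145000 nM. Going by the values given here, compound 2 stands at the lowest of the two numbers, though the single step, a 1.5-fold lower number from compound 1 to compound 2 (0.17 log units; within the scatter), lies within the scatter. Compound 3 `Cc1ccc(-c2nn(-c3ccccc3)cc2-c2nc3ccccc3n2C(=O)c2ccncc2)cc1` differs from compound 2 by pyridin-4-yl in place of 6-methylpyridin-3-yl on a carbonyl carbon. Among the compounds with values here, the only step bearing on this change is a 1.5-fold lower number from compound 1 to compound 2 (0.17 log units; within the scatter), which also exchanged the aryl group on the carbonyl carbon and produced no step beyond the scatter. Accordingly, no step beyond the scatter is expected, a 1.2-fold higher number from compound 2 to compound 3 (0.07 log units; within the scatter). Compound 3 is therefore estimated at 170000 nM, ranging from 70000 nM to 400000 nM.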

Compound 3, half-maximal cytotoxic concentration: 154000 nM
For compound 3 the middle estimate is 1.1-fold (0.04 log units) above the measured one, and the stated range covers the measured number.
By their numbers in this assay, from the lowest: compounds 2, 3 and 1 (each within the scatter of the next).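

Placing pyridin-4-yl on the carbonyl carbon gives a 1.1-fold higher number from compound 2 to compound 3 (0.03 log units; within the scatter) and a 1.4-fold lower number from compound 1 to compound 3 (0.15 log units; within the scatter) in this assay. Three different six-membered aromatic rings at this place therefore read alike, and removing the methyl group while shifting the ring nitrogen moves the number by no more than the scatter. No measured evidence explains this closeness. Still open, going by these compounds, is whether the same holds for a group that is not an aromatic ring. An amine or a longer alkyl chain on this carbonyl carbon could give a different number.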